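A few compounds are considered here, and "the series" means these few. Any claim that something is new, unique, unknown or untested is made for them only; others in the source may bear on it.

Compound 1 `c1ccc(CNCC2CCN(CCCc3c[nH]c4ccc(-n5cnnc5)cc34)CC2)cc1`: 1.6 nM
Compound 2 `c1ccc2c(c1)CCC2NCC1CCN(CCCc2c[nH]c3ccc(-n4cnnc4)cc23)CC1`: 1.1 nM

In an assay on CHO cells for displacement of a labelled ligand from 5-hydroxytryptamine receptor 1D (Homo sapiens) (on this read-out higher numbers stand for weaker inhibition and lower numbers for stronger inhibition), compound 2 gives 1.1 nM, and compound 1 gives 1.6 nM. The step of a 1.5-fold lower number from compound 1 to compound 2 (0.16 log units; within the scatter) lies within the scatter, so the two compounds are not told apart on these numbers; compound 2 simply has the nearest neighbour in compound 1.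

Compound 3 `C[C@H](NCC1CCN(CCCc2c[nH]c3ccc(-n4cnnc4)cc23)CC1)c1ccccc1` carries the change (1-phenylethyl in place of 2,3-dihydro-1H-inden-1-yl on an amine nitrogen). For the measured compounds named here, the only measured step that bears on this is the one from compound 1 to compound 2, in which a benzyl on the same amine nitrogen was exchanged for 2,3-dihydro-1H-inden-1-yl: a 1.5-fold lower number from compound 1 to compound 2 (0.16 log units; within the scatter), within the scatter. The 1-phenylethyl group of compound 3 keeps the aromatic ring of both earlier groups, so no step beyond the scatter is expected in this assay, in either direction. Compound 3 is therefore estimated at 1.3 nM, in the range 0.6 nM to 3 nM, which means an expected step of a 1.2-fold higher number from compound 2 to compound 3 (0.07 log units; within the scatter).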

Compound 3, half-maximal inhibitory concentration: 4.4 nM
For compound 3 the middle estimate is 3.4-fold (0.53 log units) below the measured one; measured number above the stated range.
By their numbers in this assay, from the lowest: compounds 2 and 1 (each within the scatter of the next); then compound 3.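

This amine nitrogen does not accept every group that carries the aromatic ring equally in this assay: the exchange of 2,3-dihydro-1H-inden-1-yl for 1-phenylethyl gives a modest step beyond the scatter (a 4.0-fold higher number from compound 2 to compound 3 (0.60 log units; beyond the scatter)), unlike the earlier exchange of benzyl. A single methyl in place of hydrogen on the saturated chain carbon bound to the amine nitrogen and an aromatic carbon is also enough for a modest step beyond the scatter (a 2.8-fold higher number from compound 1 to compound 3 (0.44 log units; beyond the scatter)), though compound 2 shows that a further carbon substituent there does not always separate a compound from compound 1. Nothing available here accounts for these differences.

From the compounds shown here alone, whether the other configuration of 1-phenylethyl would give a different number remains open, since compound 3 has one defined stereocentre. So does the response of this position to a 2-phenylethyl or a cyclohexylmethyl group.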